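Azide for Methoxy on a Weakly Cytotoxic Chromone Pair

The compounds below may be only part of what the source reports. "The series", "measured", "known", "first", "only" and "open" are said of these compounds alone.

Compound 1 `CCCCCCc1c(F)c(N)c2c(=O)cc(-c3ccc(N)c(F)c3)oc2c1F` and compound 2 `COc1c(F)c(N)c2c(=O)cc(-c3ccc(N)c(F)c3)oc2c1F` share one core and differ only at a single aromatic carbon, where compound 1 carries a hexyl chain and compound 2 a methoxy group. In a functional assay on HeLa cells (Homo sapiens) for cytotoxicity, read by neutral red uptake, with a stated time of 3 days (a lower number here means a stronger inhibitor, a higher number a weaker inhibitor), compound 1 gives 21000 nM. In this assay compound 2 gives 34000 nM. On these two numbers compound 2 stands beside compound 1, the step of a 1.6-fold higher number from compound 1 to compound 2 (0.21 log units; within the scatter) lying within the scatter, so neither number can be called higher or lower with confidence.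

Compound 3 `[N-]=[N+]=Nc1c(F)c(N)c2c(=O)cc(-c3ccc(N)c(F)c3)oc2c1F` takes the next step at the same carbon: azido in place of methoxy on an aromatic carbon. Within the data shown here, the only measured step that bears on this change is the one at that same position, from compound 1 to compound 2, which stayed within the scatter. With an exchange of one small group for another at a carbon that has already tolerated a hexyl chain and a methoxy group without a step beyond the scatter, no step beyond the scatter is expected in this assay either, in either direction. Compound 3 is therefore expected to give 30000 nM, within a range of 12000 nM to 80000 nM. The expected step is a 1.1-fold lower number from compound 2 to compound 3 (0.05 log units; within the scatter), small and within the scatter.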

Compound 3, half-maximal inhibitory concentration: 1200 nM
Compound 3: middle estimate off by 25-fold (1.40 log units), on the high side; measured number outside the range, below it.
By their numbers in this assay, from the lowest: compound 3; then compounds 1 and 2 (each within the scatter of the next).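

This carbon is not indifferent to what it carries in this assay: hexyl and methoxy could not be told apart there, yet azido in place of methoxy gives a 28-fold lower number from compound 2 to compound 3 (1.45 log units; beyond the scatter), and azido in place of hexyl gives an 18-fold lower number from compound 1 to compound 3 (1.24 log units; beyond the scatter). Both steps end at the same compound and start from two groups as unlike as a hexyl chain and a methoxy group, so among these three compounds the lower number does not depend on which of the two groups azido replaces. Nothing available here explains why azido stands apart from the other two groups at this carbon.

On these data alone, whether the lower number belongs to azido alone, or would also come with an amine or a nitrile on the same carbon, remains open. Also open, as far as these compounds go, is whether azido would give a similar step on a core lacking the two fluoro groups, and whether compound 3 would keep its standing against compound 1 and compound 2 in cells other than HeLa.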